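From a heptyl chain to hydrogen

The compounds below may be only part of what the source reports. "The series", "measured", "known", "first", "only" and "open" are said of these compounds alone.

Compound 1 `CCc1ccccc1NS(=O)(=O)c1ccc(N2CCNC2=O)cc1` gives 180 nM
Compound 2 `CCCCCCCc1ccc(NS(=O)(=O)c2ccc(N3CCNC3=O)cc2)cc1` gives > 1000 nM

In a functional assay on M21 cells (Homo sapiens) for antiproliferative activity, read by sulforhodamine B assay, with a stated time of 48 h (on this read-out lower numbers stand for stronger inhibition and higher numbers for weaker inhibition), compound 1 gives 180 nM as a measured number. Compound 2 stands at > 1000 nM as a limit of the assay and not a number.

Among the compounds with values here, compound 3 `O=C1NCCN1c1ccc(S(=O)(=O)Nc2ccccc2)cc1` differs from compound 2 by hydrogen in place of heptyl on an aromatic carbon as its single change, hydrogen in place of heptyl on an aromatic carbon. Within the data shown here, no measured step covers this change, so any forecast in this assay is uncertain. A modest shift toward stronger inhibition is expected, and this expectation leans on compound 1 at 180 nM as a member of the series without the heptyl chain. The expected move is an at least 1.2-fold lower number from compound 2 to compound 3 (0.09 log units; that floor lies within the scatter) on this estimate, and the result may still fall at the limit of the assay. For compound 3 the estimated value is 800 nM with an expected range of 250 nM to 3000 nM in this assay.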

Compound 3, half-maximal inhibitory concentration: 200 nM
For compound 3 the middle estimate is 4.0-fold (0.60 log units) above the measured one; the whole stated range lies above it.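

In this assay, the change at this aromatic carbon, para to a large group, now has a measured size: taking away the heptyl chain gives an at least 5.0-fold lower number from compound 2 to compound 3 (0.69 log units; beyond the scatter). The ethyl chain of compound 1 sits elsewhere on the ring, and replacing it with hydrogen gives a 1.1-fold higher number from compound 1 to compound 3 (0.05 log units; within the scatter), so that ethyl chain and hydrogen cannot be told apart here. For compound 2 the value is a limit of the assay and not a number, so the first step is only a floor: the limit of > 1000 nM in this assay, at which 1 of the 3 values shown sits.

The compounds shown leave open how short a chain on this carbon must be to read like hydrogen, since a butyl chain there could fall on either side. They also leave open how a hydroxyl group or an amine would read at the same carbon.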